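A few compounds are considered here, and "the series" means these few. Any claim that something is new, unique, unknown or untested is made for them only; others in the source may bear on it.

Working notes on the series. The shared core is that of compound 1 `O=C1C=CS(=O)(=O)c2ccccc21`, which in a functional assay on the whole organism for inhibition, with Mus musculus as the target, at a dose of 10 mg/kg (a lower number here means less inhibition, a higher number more inhibition at the dose given (going by the name of the read-out)), gives 5.5%. Compound 2 `CCCOCC1=CS(=O)(=O)c2ccccc2C1=O` gives 99.9% in this assay, a number that compound 3 `O=C1C(COCCCl)=CS(=O)(=O)c2ccccc21` at 98.1% matches within the scatter, and that lies far beyond compound 1. The two steps that carry the series are a number 94.4 percentage points higher from compound 1 to compound 2 (beyond the scatter) and a number 92.6 percentage points higher from compound 1 to compound 3 (beyond the scatter); each brings in a chain on a double-bonded ring carbon and each is large. By contrast a number 1.8 percentage points lower from compound 2 to compound 3 (within the scatter) shows that exchanging the end of the chain makes no difference beyond the scatter.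

Compound 4 `O=C1C(CI)=CS(=O)(=O)c2ccccc21` has not yet been run in this assay. Against compound 2 the change is iodo in place of propoxy on a saturated chain carbon bound to a double-bonded ring carbon. Going by the values given here, no measured step removes the oxygen-bearing chain while keeping a one-carbon group on the ring carbon, so the bearing of the three steps is indirect: both large steps say that a substituent at this carbon is what separates compound 2 and compound 3 from compound 1, and the small step says the outer part of that substituent is not what matters. The expected step in this assay is therefore a number 14.9 percentage points lower from compound 2 to compound 4 (beyond the scatter), small and downward at most, with a wide range to allow for the absence of a direct precedent. Compound 4 is expected to give 85%, within a range from 40% to 100%.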

Compound 4, a percentage reported as inhibition, in the whole organism at one dose (the size of the read-out at that dose, not a potency): 98%
The estimate for compound 4 lay 13 percentage points below the measured number, and the stated range covers the measured number.
By their numbers in this assay, from the lowest: compound 1; then compounds 4, 3 and 2 (each within the scatter of the next).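

In this assay, the steps of a number 1.9 percentage points lower from compound 2 to compound 4 (within the scatter) and a number 0.1 percentage points lower from compound 3 to compound 4 (within the scatter) show that iodo can take the place of propoxy or 2-chloroethoxy on a saturated chain carbon bound to a double-bonded ring carbon without a change beyond the scatter, so within these compounds neither the oxygen nor the rest of those chains is required for the read-out. Going by these compounds alone, the step of a number 92.5 percentage points higher from compound 1 to compound 4 (beyond the scatter) is large, as are the earlier steps from compound 1, so the large step now holds for an iodomethyl group as well as for the two oxygen-bearing chains. No evidence on any other property of these compounds bears on why the three groups read alike.

With compound 2 at 99.9%, compound 3 at 98.1% and compound 4 at 98%, this read-out at one dose does not separate the three, and it gives no potency order among them. Open is whether any group on this carbon would serve, since the compounds shown do not tell how a plain methyl, a hydroxymethyl or an aminomethyl group would read in this assay.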